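Swapping the Amide for an Aminoalkyl Chain at the Ring Nitrogen

The source may hold more compounds than are shown below. What is called first, only, known or untested is meant among the compounds shown, and "the series" means these compounds.

Measured so far:
compound 1 `COc1cc(-c2cnc(N)nc2-c2ccccc2)cc(OC)c1OC` — 56%
compound 2 `CCCC(=O)Nc1ncc(-c2cccc(Cl)c2)c(-c2ccccc2)n1` — > 80%

Of the compounds shown here, two have been measured in an assay on CHO cells for displacement of a labelled ligand from adenosine receptor A1 (Homo sapiens), read by scintillation counting, with a stated time of 1 h, tested at 1 uM; a higher number here means more inhibition at the concentration tested (going by the name of the read-out), a lower number less inhibition. Compound 1 gives 56%. For compound 2 the result is a limit of the assay rather than a number, reported as > 80%. That reading is the limit of > 80% in this assay, at which 1 of the 2 values shown sits, so compound 2 stands at the top of what this assay reports, and only a drop could turn its result into a number.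

Compound 3 `CN(C)CCNc1ncc(-c2cccc(Cl)c2)c(-c2ccccc2)n1` has not yet been measured. It differs from compound 2 in a single place: 2-(dimethylamino)ethyl in place of propylcarbonyl on a nitrogen on an aromatic ring. Among the measured compounds shown here, no pair of measured compounds in this set shares that change, so the size of the step has no direct anchor in the data. The expectation rests only on the fact that compound 2 sits at the limit and that the new group is a different kind of chain. Compound 3 is estimated to give 55%, with a range from 25% to 85%. The expected step is a number at least 25 percentage points lower from compound 2 to compound 3 (beyond the scatter), a fall that reaches beyond the scatter, though with wide uncertainty.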

Compound 3, a percentage reported as inhibition, at one concentration (the size of the read-out at that concentration, not a potency): 52%
Compound 3: the middle estimate sits 3 percentage points above what was measured; the range from low to high includes it.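

In this assay, among the compounds shown here, this is the first change in the set that can be read at a single place, and it shows that the group on this nitrogen is not interchangeable: 2-(dimethylamino)ethyl in place of propylcarbonyl gives a result described as a number at least 28 percentage points lower from compound 2 to compound 3 (beyond the scatter), and the reading moves off the top of the scale onto a number. The two groups match in size, each with 5 heavy atoms, no hydrogen-bond donor and 1 hydrogen-bond acceptor, so these counts alone do not separate them, while the carbonyl oxygen of one is exchanged for the amine nitrogen of the other. As far as these compounds go, the full size of the step stays unknown because the reading of compound 2 is a limit of the assay and not a number: the limit of > 80% in this assay, at which 1 of the 3 values shown sits.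

The compounds shown do not say whether the fall goes with the loss of the carbonyl or with the arrival of the dimethylamino group. A plain butyl chain on the same nitrogen would bear on that question, and a longer chain such as 3-(dimethylamino)propyl or a cyclic amine such as morpholine would show how far the aminoalkyl result extends.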